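From compound 3 to compound 4: solubility expected to fall

The compounds below may be only part of what the source reports. "The series", "measured", "known", "first", "only" and "open" are said of these compounds alone.

Within the data shown here, in a physicochemical assay for solubility, read by LC-MS, in phosphate buffer, with a stated time of 24 h, at pH 7.4 (on this read-out higher numbers stand for higher solubility and lower numbers for lower solubility), compound 3 `Cc1ncc(-c2cnc(NCc3c(F)ccc4c3CCO4)c3cn[nH]c(=O)c23)n1C` gives 15000 nM, the highest of the two actual numbers so far. Compound 1 `Cn1nccc1-c1cnc(NCc2c(F)ccc3c2CCO3)c2cn[nH]c(=O)c12` gives 2000 nM. Compound 2 `O=C1CCCN1c1cnc(NCc2c(F)ccc3c2CCO3)c2cn[nH]c(=O)c12` gives < 2000 nM, which is a limit and not a number. Compound 4 `CN(C)C(=O)c1cc(-c2cnc(NCc3c(F)ccc4c3CCO4)c3cn[nH]c(=O)c23)n(C)n1` carries 3-(dimethylcarbamoyl)-1-methyl-1H-pyrazol-5-yl in place of 1,2-dimethyl-1H-imidazol-5-yl on an aromatic carbon. The closest guide is a 7.5-fold higher number from compound 1 to compound 3 (0.88 log units; beyond the scatter), a modest step beyond the scatter. Among the measured compounds shown here, compound 4 returns to a 1-methylpyrazole ring like that of compound 1, so a modest fall is expected, although no measured step tests the added dimethylcarbamoyl group. The expected change is a 5.0-fold lower number from compound 3 to compound 4 (0.70 log units; beyond the scatter). For compound 4 the estimate is 3000 nM, with an expected range from 1000 nM to 10000 nM.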

Compound 4, solubility: 3000 nM
Beside the measured number, compound 4's estimate shows no gap at the digits printed, and the stated range covers the measured number.
By their numbers in this assay, from the lowest: compounds 1 and 4 (each within the scatter of the next); then compound 3.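

In this assay, dimethylcarbamoyl in place of hydrogen on the pyrazole ring gives a 1.5-fold higher number from compound 1 to compound 4 (0.18 log units; within the scatter), so adding this group moves the read-out no more than repeat measurements would. Replacing the 1,2-dimethyl-1H-imidazol-5-yl group gives a 5.0-fold lower number from compound 3 to compound 4 (0.70 log units; beyond the scatter), so the higher number stays with the imidazole-bearing compound. The step from the 2-oxopyrrolidin-1-yl group is an at least 1.5-fold higher number from compound 2 to compound 4 (0.17 log units; that floor lies within the scatter), and it rests on a limit: the limit of < 2000 nM in this assay, at which 1 of the 4 values shown sits.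

On these data alone, whether 1-methyl-1H-imidazol-5-yl, lacking the second methyl, keeps the higher number remains open. So does the effect of an amine in place of dimethylcarbamoyl.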